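The source may report more compounds than this note shows. Statements on the series, on what has been measured and on what is new or still open speak of the compounds shown alone.

Three compounds share a common core and were all measured in an assay on microsomes from brain for inhibition of Fatty-acid amide hydrolase 1 (Rattus norvegicus), read by fluorescence and HPLC, with a stated time of 45 min; on this read-out higher numbers stand for weaker inhibition and lower numbers for stronger inhibition. Compound 1, `O=C(COc1ccc(Oc2ccccc2)cc1)Cn1ncnn1`, gives 8 nM in this assay. Compound 2, `N#CNC(COc1ccc(Oc2ccccc2)cc1)Cn1ncnn1`, gives 5300 nM. Compound 3, `O=C(COc1ccc(Oc2ccccc2)cc1)Cn1ncc2ccccc21`, gives 2600 nM, which puts it second highest of the three numbers: its nearest neighbour is compound 2, whose number is higher, while compound 1 lies far below it. Going by the values given here, the one step between compounds that differ in a single place is a 330-fold higher number from compound 1 to compound 3 (2.51 log units; beyond the scatter), a swap of one ring system for another on the chain carbon next to the carbonyl.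

The unmeasured compound 4, `COCC(=O)Nc1ccc2c(cnn2CC(=O)COc2ccc(Oc3ccccc3)cc2)c1`, differs from compound 3 by ((methoxymethyl)carbonyl)amino in place of hydrogen on an aromatic carbon. The core and the indazole are kept; a group is simply added to the fused ring system. Among the compounds with values here, no measured step speaks to such an addition: the only step available swaps whole ring systems and says nothing about decorating the one that enters. Within the data shown here, with no comparable precedent, the expectation for compound 4 is a number in the neighbourhood of its parent, with wide uncertainty. Compound 4 is thus expected to shift by an estimated 1.3-fold lower number from compound 3 to compound 4 (0.11 log units; within the scatter). The estimate for compound 4 in this assay is 2000 nM, expected to fall between 300 nM and 10000 nM.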

Compound 4, half-maximal inhibitory concentration: 6300 nM
Compound 4: middle estimate off by 3.2-fold (0.50 log units), on the low side; measured number inside the range.
By their numbers in this assay, from the lowest: compound 1; then compound 3; then compounds 2 and 4 (each within the scatter of the next).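

In this assay, going by these compounds alone, placing ((methoxymethyl)carbonyl)amino in place of hydrogen on an aromatic carbon of the fused ring system gives a 2.4-fold higher number from compound 3 to compound 4 (0.38 log units; beyond the scatter) and is the first measured change that adds to this ring system instead of swapping it whole. A group of 6 heavy atoms at this carbon therefore weakens inhibition only modestly, and this step is small beside a 330-fold higher number from compound 1 to compound 3 (2.51 log units; beyond the scatter) in the same assay, so here the swap of ring systems counts for far more than the addition. The data shown offer no explanation for the size of this new step.

From the compounds shown here alone, it stays open which part of the entering group produces the shift, since a plain amine, a shorter acetylamino group or a carboxylic acid on this same carbon would be needed to separate the amide from its methoxymethyl end. Also open, going by these compounds, is whether ((methoxymethyl)carbonyl)amino would have a similar effect on another carbon of this six-membered ring, and whether any group here can bring the number back towards that of compound 1 at 8 nM in this assay.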